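A few compounds are considered here, and "the series" means these few. Any claim that something is new, unique, unknown or untested is made for them only; others in the source may bear on it.

Measured compounds:
- compound 1, `CC1=C(C(=O)OCc2ccccc2)C(c2ccsc2)NC(=O)N1`: 25%
- compound 2, `CC1=C(C(=O)C2CC2)C(c2ccsc2)NC(=O)N1`: 1%
- compound 3, `CCNC(=O)C1=C(C)NC(=O)NC1c1ccsc1`: 1%

In an assay on membranes from HeLa cells for displacement of a labelled ligand from adenosine receptor A3 (Homo sapiens), read by scintillation counting, with a stated time of 180 min, tested at 1 uM (on this read-out higher numbers stand for more inhibition at the one concentration tested (going by the name of the read-out) and lower numbers for less inhibition), compound 3 gives 1%, level with compound 2 at 1%; together these two are the lowest of the three numbers. Compound 1 at 25% stands higher than compound 3, beyond the scatter. Among the measured compounds shown here, the only measured step between neighbours is no change at the digits printed from compound 2 to compound 3 (within the scatter), so exchanging a ketone for an amide on the carbonyl carbon moved nothing.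

Compound 4, `CCC(CC)OC(=O)C1=C(C)NC(=O)NC1c1ccsc1`, differs from compound 3 by (pentan-3-yl)oxy in place of ethylamino on a carbonyl carbon. For the measured compounds named here, no measured step swaps an amide for an ester directly. Going by the values given here, the one compound that carries an oxygen-linked group on that carbonyl carbon is compound 1, and it is the only one above the floor; the other two, both without such a group, sit at the floor. Among the compounds with values here, on this slim basis a rise is expected for compound 4, of about a number 14 percentage points higher from compound 3 to compound 4 (beyond the scatter), with wide uncertainty since the group entering is not the one compound 1 carries. The estimate for compound 4 is 15%, in the range 0% to 35%.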

Compound 4, a percentage reported as inhibition, at one concentration (the size of the read-out at that concentration, not a potency): 6%
The estimate for compound 4 lay 9 percentage points above the measured number; low and high end bracket the measured number.
By their numbers in this assay, from the lowest: compounds 2, 3 and 4 (each within the scatter of the next); then compound 1.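

Placing (pentan-3-yl)oxy on the carbonyl carbon in place of ethylamino gives a number 5 percentage points higher from compound 3 to compound 4 (within the scatter) in this assay and in place of cyclopropyl gives a number 5 percentage points higher from compound 2 to compound 4 (within the scatter), so an oxygen link at this position does not by itself separate compound 4 from the amide or the ketone. The group on that oxygen does count in this one pair, where pentan-3-yl in place of benzyl gives a number 19 percentage points lower from compound 1 to compound 4 (beyond the scatter) and the higher number of compound 1 goes with benzyl rather than with the ester link alone. No measurement available here explains this difference.

On these data alone, whether the ring of benzyl is what matters remains open, and cyclohexylmethyl or phenethyl on the same oxygen would test this. As far as these compounds go, whether benzylamino on the carbonyl carbon would match the benzyl ester also remains open.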